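The source may hold more compounds than are shown below. What is called first, only, known or untested is meant among the compounds shown, and "the series" means these compounds.

Working notes on the series. Within the data shown here, compound 3 `C#Cc1cn([C@@H]2O[C@H](CO)[C@@H](O)[C@H]2O)c2ncnc(OC)c12` is the only member with a number in a functional assay on HeLa S3 cells (Homo sapiens) for antiproliferative activity, read by XTT assay, with a stated time of 72 h; on this read-out higher numbers stand for weaker inhibition and lower numbers for stronger inhibition: in this assay compound 3 gives 1730 nM. Compound 1 `Nc1nc(N)c2c(-c3ccsc3)cn([C@@H]3O[C@H](CO)[C@@H](O)[C@H]3O)c2n1` gives only a limit of the assay, > 20000 nM. Compound 2 `Nc1nc(N)c2c(-c3cc4ccccc4o3)cn([C@@H]3O[C@H](CO)[C@@H](O)[C@H]3O)c2n1` likewise gives only a limit, > 20000 nM. Among the measured compounds shown here, the single measured step, a step that the two limits leave unreadable from compound 1 to compound 2, is for that reason unreadable, and the evidence from the measured pairs amounts to the limit of > 20000 nM in this assay, at which 2 of the 3 values shown sit. The change ahead runs from compound 3 to compound 4 `COc1ncnc2c1c(-c1cccs1)cn2[C@@H]1O[C@H](CO)[C@@H](O)[C@H]1O`: thiophen-2-yl in place of ethynyl on an aromatic carbon. For the measured compounds named here, no measured step covers this change, and the pair of compound 1 and compound 2 rests on a different core, so no number can be carried over from it and no direction can be drawn from the compounds in hand. The expectation for compound 4 is therefore a step of a 1.3-fold lower number from compound 3 to compound 4 (0.12 log units; within the scatter), which is no shift beyond the scatter. Compound 4 is estimated at 1300 nM, with a range from 250 nM to 7000 nM.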

Compound 4, half-maximal inhibitory concentration: 1760 nM
For compound 4 the middle estimate is 1.4-fold (0.13 log units) below the measured one; the range from low to high includes it.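

In this assay, the position two ring bonds from the ring nitrogen takes thiophen-2-yl in place of ethynyl with the read-out unmoved, a 1.0-fold higher number from compound 3 to compound 4 (0.01 log units; within the scatter), so a five-membered aromatic ring and a triple bond are not told apart here on the shared core. Among these compounds, the step from compound 1 to compound 2 cannot be read, which leaves this as the only readable step. Nothing measured in the compounds shown gives a reason for this flat result.

From the compounds shown here alone, whether an amine, a carboxylic acid or a longer chain at this position would shift the number stays open. Also open, going by these compounds, is whether thiophen-3-yl or 1-benzofuran-2-yl would give the same result on the core of compound 3.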